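From Compound 2 to Compound 3: a Smaller Heteroaryl Arm

The compounds below may be only part of what the source reports. "The series", "measured", "known", "first", "only" and "open" are said of these compounds alone.

Compound 1 `CCC(C)(C)Cc1c[nH]c(CCc2ccc(-c3ccncc3)cc2)n1` gives 101 nM in an in vitro assay on CHO cells for displacement of a labelled ligand from Bombesin receptor subtype-3 (Homo sapiens), read by scintillation counting, with a stated time of 2 h; on this read-out higher numbers stand for weaker inhibition and lower numbers for stronger inhibition. Compound 2 `CCC(C)(C)Cc1c[nH]c(CCc2ccc(-c3cccnc3C(=O)O)cc2)n1`, which carries 2-carboxypyridin-3-yl in place of pyridin-4-yl, gives 560 nM in this assay; that change was a 5.5-fold higher number from compound 1 to compound 2 (0.74 log units; beyond the scatter). Among the two numbers so far, compound 2 stands highest, with compound 1 as its only neighbour, and the gap between them lies beyond the scatter.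

Compound 3 `CCC(C)(C)Cc1c[nH]c(CCc2ccc(-c3ccns3)cc2)n1` has not yet been measured. It differs from compound 2 by 1,2-thiazol-5-yl in place of 2-carboxypyridin-3-yl on an aromatic carbon. Among the compounds with values here, only one measured step bears on this change: a 5.5-fold higher number from compound 1 to compound 2 (0.74 log units; beyond the scatter), in which the 2-carboxypyridin-3-yl group entered. Within the data shown here, compound 3 removes that group again and puts a different small heteroaryl in its place, so the number is expected to move back toward compound 1, though 1,2-thiazol-5-yl itself has no measured precedent here. The step is expected to be a 3.7-fold lower number from compound 2 to compound 3 (0.57 log units; beyond the scatter). Compound 3 is therefore estimated at 150 nM in this assay, within a range of 50 nM to 450 nM.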

Compound 3, half-maximal inhibitory concentration: 11 nM
Beside the measured number, compound 3's estimate is 14-fold (1.13 log units) above it, and the stated range ends above it.
By their numbers in this assay, from the lowest: compound 3; then compound 1; then compound 2.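

At this aromatic carbon, para to a large group, the step of a 51-fold lower number from compound 2 to compound 3 (1.71 log units; beyond the scatter) does more than reverse the earlier loss, as the step of a 9.2-fold lower number from compound 1 to compound 3 (0.96 log units; beyond the scatter) shows. The earlier compounds shown here showed only a weaker result when one six-membered aromatic ring replaced another here, whereas the five-membered aromatic ring with 2 hetero atoms in 1,2-thiazol-5-yl gives the lowest of the three numbers in this assay and lies beyond the scatter from both neighbours. Nothing shown accounts for this gain.

The compounds shown leave open whether the gain follows the sulfur atom or the smaller ring, a question that a thiophene or a 1,3-thiazole at this carbon would address. They also leave open whether an amine or a carboxylic acid on the 1,2-thiazol-5-yl ring would keep the number low.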